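Branched Ether in Place of Cyclopentylmethyl on the Ring Nitrogen

The source may hold more compounds than are shown below. What is called first, only, known or untested is meant among the compounds shown, and "the series" means these compounds.

Of the compounds shown here, three built on a shared core have been measured in an assay on HEK293 cells for displacement of a labelled ligand from growth hormone secretagogue receptor type 1 (Homo sapiens), with a stated time of 60 min; on this read-out lower numbers stand for stronger inhibition and higher numbers for weaker inhibition. Compound 1 `Cc1ncccc1-c1nc2cn(-c3cccc(OC(C)C)c3)nc2c(=O)n1C[C@H]1CCCN(C[C@H]2CCCO2)C1` gives 11 nM there. Compound 2 `COc1cccc(-n2cc3nc(-c4ccccc4C)n(CC4CCCN(C(C)C)C4)c(=O)c3n2)c1` gives 1.8 nM in this assay. Compound 3 `COc1cccc(-n2cc3nc(-c4cccnc4C)n(C[C@H]4CCCN(CC5CCCC5)C4)c(=O)c3n2)c1` gives 12 nM in this assay, the highest of the three numbers: its value lies within the scatter of that of compound 1, while compound 2 sits well below it, beyond the scatter. Compound 2 differs from compound 3 in more than one place, so that gap cannot be assigned to any single change.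

Compound 4 `COC[C@H](C)N1CCC[C@H](Cn2c(-c3cccnc3C)nc3cn(-c4cccc(OC)c4)nc3c2=O)C1` has not yet been measured. It differs from compound 3 in one place: 1-(methoxymethyl)ethyl in place of cyclopentylmethyl on an amine nitrogen in a ring. For the measured compounds named here, no measured pair isolates this change. The nearest hint comes from compound 2, which carries a branched group on the same amine nitrogen and gives 1.8 nM in this assay, yet compound 2 also differs from compound 3 elsewhere. For compound 4 a small move towards a lower number is expected, a 1.5-fold lower number from compound 3 to compound 4 (0.18 log units; within the scatter). A result within the scatter of compound 3 would also be unsurprising. Compound 4 is therefore estimated at 8 nM in this assay, with a range from 3 nM to 25 nM.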

Compound 4, half-maximal inhibitory concentration: 1.7 nM
Compound 4: the middle estimate sits 4.7-fold (0.67 log units) above what was measured; the whole stated range lies above it.
By their numbers in this assay, from the lowest: compounds 4 and 2 (each within the scatter of the next); then compounds 1 and 3 (each within the scatter of the next).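

In this assay, putting 1-(methoxymethyl)ethyl in place of cyclopentylmethyl on the amine nitrogen in the ring gives a 7.1-fold lower number from compound 3 to compound 4 (0.85 log units; beyond the scatter) and so provides the first pair among these compounds that isolates a change at this position. With the rest of compound 3 held fixed, the step lies beyond the scatter, which shows that the number in this assay depends on the group this nitrogen carries. Here, a group with no ring, 5 heavy atoms including 1 oxygen, 1 hydrogen-bond acceptor and 1 defined stereocentre goes with the lower number, but no measurement is available to explain the step.

The compounds shown leave open which feature of the entering group goes with the step, as the ether oxygen, the branching, the absence of the cyclopentane ring and the defined stereocentre all change together. From the compounds shown here alone, it also remains open how a 1-(hydroxymethyl)ethyl group or a sec-butyl group on this nitrogen would compare, and whether the opposite configuration at the new stereocentre would give a similar number.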